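The source may hold more compounds than are shown below. What is called first, only, known or untested is meant among the compounds shown, and "the series" means these compounds.

Measured compounds in an ADME assay on microsomes from liver (Mus musculus) for metabolic stability, read by LC-MS, using NADPH, with a stated time of 30 min, tested at 0.5 uM; on this read-out lower numbers stand for slow clearance and higher numbers for fast clearance:

- compound 1 `Cc1ccc(CN2CCC3(CC2)OCCc2sccc23)cc1`: in this assay compound 1 gives > 30 mL/min/g, a limit of the assay.
- compound 2 `Cc1cccc(CN2CCC3(CC2)OCCc2sccc23)c1`: in this assay compound 2 gives > 30 mL/min/g, likewise a limit.
- compound 3 `Cc1ccccc1CN1CCC2(CC1)OCCc1sccc12`: in this assay compound 3 gives "not determined" (no result reported), so no number is reported for it.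

Compound 2 therefore stands at the limit of the read-out, and the two limits leave no order between compound 2 and compound 1. Going by the values given here, the single step among the measured pair, a step that the two limits leave unreadable from compound 1 to compound 2, cannot be sized because of the limit of > 30 mL/min/g in this assay, at which 2 of the 3 values shown sit. Compound 3 contributes no number.

The next compound, compound 4 `Cc1ccc(CN2CCC3(CC2)OCCc2sccc23)cc1C`, differs from compound 2 by methyl in place of hydrogen on an aromatic carbon. Among the compounds with values here, no measured step covers this change: the one step in hand, a step that the two limits leave unreadable from compound 1 to compound 2, is unreadable, so nothing points to a shift in either direction, and nothing argues for a move away from the limit. The step from compound 2 to compound 4 is thus expected to be a step that the limit leaves unreadable from compound 2 to compound 4, that is, nothing beyond the scatter. Compound 4 is estimated at 45 mL/min/g in this assay, with a range from 20 mL/min/g to 100 mL/min/g, and a high chance that only a limit is again reported.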

Compound 4, intrinsic clearance in a liver preparation (reported as CLH), per the amount of preparation that the assay uses: > 30 mL/min/g
Compound 4: only a limit was reported; the forecaster's own chance of this, stated with the estimate: 80%; the middle value is on the limit's open side.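

In this assay compound 4 gives > 30 mL/min/g, again a limit of the assay. No new step can be read among compound 1, compound 2 and compound 4, because all three sit at the same limit: the limit of > 30 mL/min/g in this assay, at which 3 of the 4 values shown sit. The compounds shown leave open the actual clearance of each, and so whether methyl in place of hydrogen on an aromatic carbon changes it at all.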